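The compounds below may be only part of what the source reports. "The series", "measured", "known", "first", "only" and "open" are said of these compounds alone.

In an in vitro functional assay on cells (Fibroblast) for agonist activity at Alpha-1B adrenergic receptor (Homo sapiens) (on this read-out lower numbers stand for an effect already at smaller amounts and higher numbers for an effect only at larger amounts of compound), compound 1 `c1ccc(-c2nc[nH]n2)c(NCC2=NCCN2)c1` gives 5.01 nM, the lowest of the two numbers recorded; compound 2 `CCCCn1ncnc1-c1ccccc1NCC1=NCCN1` gives 200 nM in this assay, a much higher number that lies beyond the scatter. Compound 3 `Cn1cc(-c2ccccc2NCC2=NCCN2)cn1` has not yet been measured. It differs from compound 1 in one place: 1-methyl-1H-pyrazol-4-yl in place of 1H-1,2,4-triazol-3-yl on an aromatic carbon. Within the data shown here, no measured pair shows this exact change, so the step can only be expected, not read off. Given that compound 1 stands at 5.01 nM, compound 3 is estimated to come out weaker, at about 50 nM, somewhere between 10 nM and 250 nM, which would mean a step of a 10-fold higher number from compound 1 to compound 3 (1.00 log units; beyond the scatter) in this assay.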

Compound 3, half-maximal effective concentration: < 100000 nM
Compound 3: only a limit was reported; the forecaster's own chance of this, stated with the estimate: 5%; the middle value is on the limit's open side.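

In this assay, among these compounds, compound 3 gives only a limit of < 100000 nM and not a number, so no step from compound 1 to compound 3 can be read. On these data alone, how much putting 1-methyl-1H-pyrazol-4-yl in place of 1H-1,2,4-triazol-3-yl changes the value in this assay stays open.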